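A few compounds are considered here, and "the series" means these few. Any claim that something is new, unique, unknown or untested is made for them only; others in the source may bear on it.

Compound 1 `O=C(C1=C(OC2CCCCC2)C(=O)N(CCCn2ccnc2)C1c1ccc(Br)cc1)c1ccccc1` was tested in a functional assay on SAOS-2 cells (Homo sapiens) for antiproliferative activity, read by MTT assay, with a stated time of 72 h (a higher number here means a weaker inhibitor, a lower number a stronger inhibitor), where compound 1 gives 29700 nM. Two close relatives were run in the same setting: compound 2 `Cc1ccc(NC2=C(C(=O)c3ccccc3)C(c3ccc(Br)cc3)N(CCCn3ccnc3)C2=O)cc1` gives 31900 nM in this assay, and compound 3 `CCOc1ccc(NC2=C(C(=O)c3ccccc3)C(c3ccc(Br)cc3)N(CCCn3ccnc3)C2=O)cc1` gives 30900 nM. Among these three numbers compound 1 holds the lowest, but only by the narrowest of margins: the step of a 1.0-fold higher number from compound 1 to compound 3 (0.02 log units; within the scatter) and the step of a 1.1-fold higher number from compound 1 to compound 2 (0.03 log units; within the scatter) both sit within the scatter, so the three compounds are indistinguishable on this read-out. The same holds for a 1.0-fold lower number from compound 2 to compound 3 (0.01 log units; within the scatter).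

Compound 4 `O=C(C1=C(Nc2ccc(Br)cc2)C(=O)N(CCCn2ccnc2)C1c1ccc(Br)cc1)c1ccccc1` has not yet been measured. Relative to compound 1 the change is (4-bromophenyl)amino in place of cyclohexyloxy on a double-bonded ring carbon. The two steps that bear on it are those in which an arylamino group replaced the same cyclohexyloxy group, namely a 1.1-fold higher number from compound 1 to compound 2 (0.03 log units; within the scatter) and a 1.0-fold higher number from compound 1 to compound 3 (0.02 log units; within the scatter), and neither moved the number beyond the scatter. On that basis compound 4 is expected to show no step beyond the scatter in this assay, with an estimated shift of a 1.0-fold higher number from compound 1 to compound 4 (0.00 log units; within the scatter). The estimate for compound 4 is therefore 30000 nM, with a range from 15000 nM to 60000 nM.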

Compound 4, half-maximal inhibitory concentration: 23800 nM
Compound 4: the middle estimate sits 1.3-fold (0.10 log units) above what was measured; low and high end bracket the measured number.
By their numbers in this assay, from the lowest: compounds 4, 1, 3 and 2 (each within the scatter of the next).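

In this assay the replacement of cyclohexyloxy by (4-bromophenyl)amino on the double-bonded ring carbon gives a 1.2-fold lower number from compound 1 to compound 4 (0.10 log units; within the scatter) and, like the two earlier arylamino compounds, stays within the scatter, so this third aryl substituent adds to the evidence that exchanging the non-aromatic carbon ring for an aromatic one and bringing in the hydrogen-bond donor leaves the read-out unresolved. It also extends the comparison on the aromatic ring to a halogen: bromo in place of ethoxy gives a 1.3-fold lower number from compound 3 to compound 4 (0.11 log units; within the scatter) and bromo in place of methyl gives a 1.3-fold lower number from compound 2 to compound 4 (0.13 log units; within the scatter), so methyl, ethoxy and bromo cannot be told apart in this series. No independent measurement is available to explain why these compounds read alike.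

The compounds shown leave open whether anything at this carbon would step beyond the scatter, such as a piperidine, a carboxylic acid or a longer alkyl chain in place of the arylamino group. They also leave open what the benzoyl, 4-bromophenyl and 3-(1H-imidazol-1-yl)propyl groups contribute, since all three stay the same throughout.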